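The source may report more compounds than this note shows. Statements on the series, on what has been measured and on what is new or still open speak of the compounds shown alone.

Measured in a functional assay on SMMC-7721 cells (Homo sapiens) for cytotoxicity, read by MTT assay, with a stated time of 24 h; on this read-out higher numbers stand for weaker inhibition and lower numbers for stronger inhibition:
- Compound 1 `CN1C/C(=C\c2cccnc2)C(=O)/C(=C/c2ccccc2F)C1`: 5420 nM
- Compound 2 `O=C1/C(=C/c2cccnc2)CNC/C1=C\c1ccccc1F`: > 20000 nM (a limit of the assay, not a number)
- Compound 3 `Cc1ccc(S(=O)(=O)N2C/C(=C\c3cccnc3)C(=O)/C(=C/c3ccccc3F)C2)cc1`: 10300 nM

Within the data shown here, compound 3 stands level with the only other exact number, and the gap is a 1.9-fold higher number from compound 1 to compound 3 (0.28 log units; within the scatter). Compound 4 `O=C1/C(=C/c2cccnc2)CN(S(=O)(=O)c2ccc(C(F)(F)F)cc2)C/C1=C\c1ccccc1F` differs from compound 3 in one place: trifluoromethyl in place of methyl on an aromatic carbon. Trifluoromethyl takes the place of methyl on an aromatic carbon, para to a large group, turning 4-methylphenyl into 4-(trifluoromethyl)phenyl.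

Among the measured compounds shown here, no measured step touches this position, so the closest guide comes from changes on the ring nitrogen. For the measured compounds named here, removing the methyl gave an at least 3.6-fold higher number from compound 1 to compound 2 (0.56 log units; beyond the scatter), the one step beyond the scatter. Adding the sulfonyl group to the bare nitrogen gave an at least 1.9-fold lower number from compound 2 to compound 3 (0.28 log units; that floor lies within the scatter), which rests on a limit and sets only a floor. Since the whole (4-methylphenyl)sulfonyl in place of methyl stayed within the scatter, the smaller edit here is expected to do the same in this assay, with an expected step of a 1.2-fold lower number from compound 3 to compound 4 (0.08 log units; within the scatter). For compound 4 the estimated value is 8500 nM, with an expected range of 3500 nM to 19000 nM.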

Compound 4, half-maximal inhibitory concentration: 7900 nM
Compound 4: the middle estimate sits 1.1-fold (0.03 log units) above what was measured, within the range that was stated.
By their numbers in this assay, from the lowest: compounds 1, 4 and 3 (each within the scatter of the next). At a limit, above all of these: compound 2.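

Every earlier step changed the group on the ring nitrogen; this one leaves that nitrogen's sulfonyl link in place and alters only its aromatic ring, turning 4-methylphenyl into 4-(trifluoromethyl)phenyl. In this assay this gives a 1.3-fold lower number from compound 3 to compound 4 (0.12 log units; within the scatter), so at this position trifluoromethyl can stand in for methyl with no shift that can be told from the scatter. No measurement shown here bears on why the two compounds read alike.

Still open, from the compounds shown here alone, is whether an amine or a carboxylic acid at this same position would move the number beyond the scatter. Also open, going by these compounds, is whether the same swap from methyl to trifluoromethyl would read the same way on another aromatic carbon of this ring.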